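Nitro for methoxy on the aryl of compound 3

The source may report more compounds than this note shows. Statements on the series, on what has been measured and on what is new or still open speak of the compounds shown alone.

The three measured compounds share one core and differ at the aryl on the thiadiazole nitrogen and at the acyl group. Going by the values given here, in a functional assay on MCF7 cells (Homo sapiens) for cytotoxicity, read by sulforhodamine B assay, with a stated time of 72 h (a lower number here means a stronger inhibitor, a higher number a weaker inhibitor), compound 3 `CCOC(=O)c1nn(-c2ccc(OC)cc2)/c(=N/c2nc(-c3c(C)n(C)n(-c4ccccc4)c3=O)cs2)s1` gives 15900 nM, the only actual number among the three. Compound 2 `CCOC(=O)c1nn(-c2ccccc2)/c(=N/c2nc(-c3c(C)n(C)n(-c4ccccc4)c3=O)cs2)s1` returns a limit, > 100000 nM. Compound 1 `CC(=O)c1nn(-c2ccc([N+](=O)[O-])cc2)/c(=N/c2nc(-c3c(C)n(C)n(-c4ccccc4)c3=O)cs2)s1`, which carries a nitro group and an acetyl in place of the ethyl ester, also returns a limit, > 100000 nM. Among the compounds with values here, the single measured step is an at least 6.2-fold lower number from compound 2 to compound 3 (0.79 log units; beyond the scatter); both other values sit at the limit of > 100000 nM in this assay, at which 2 of the 3 values shown sit.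

Compound 4 `CCOC(=O)c1nn(-c2ccc([N+](=O)[O-])cc2)/c(=N/c2nc(-c3c(C)n(C)n(-c4ccccc4)c3=O)cs2)s1` differs from compound 3 by nitro in place of methoxy on an aromatic carbon. The step that bears on it is the one that brought the methoxy in, since that group is what separates compound 3 from a limit value. Nitro appears only in compound 1, together with a different acyl group, so no step for nitro alone is known. Taking away the methoxy and placing the group present in compound 1 is expected to raise the number in this assay, probably back toward the limit. Compound 4 is therefore estimated at 80000 nM, within a range from 20000 nM to 200000 nM. The expected step of a 5.0-fold higher number from compound 3 to compound 4 (0.70 log units; beyond the scatter) is upward and well beyond the scatter.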

Compound 4, half-maximal inhibitory concentration: 10000 nM
Estimate against measurement, compound 4: 8.0-fold (0.90 log units) above; measured number below the stated range.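

In this assay, the change from 4-methoxyphenyl to 4-nitrophenyl gives a 1.6-fold lower number from compound 3 to compound 4 (0.20 log units; within the scatter), so the two groups are not told apart at this place, para to a large group, and the drop seen in an at least 6.2-fold lower number from compound 2 to compound 3 (0.79 log units; beyond the scatter) is not particular to methoxy, as an at least 10-fold lower number from compound 2 to compound 4 (1.00 log units; beyond the scatter) also shows. The acyl group now counts as well: with the 4-nitrophenyl held constant, ethoxy in place of methyl on the carbonyl carbon gives an at least 10-fold lower number from compound 1 to compound 4 (1.00 log units; beyond the scatter), so nitro on the aryl does not by itself place a compound at the limit, and compound 1 goes against any reading that a para group on the aryl is enough. The true size of the steps that start from compound 1 or compound 2 stays unknown, since each of these two compounds gives only a limit and not a number: the limit of > 100000 nM in this assay, at which 2 of the 4 values shown sit.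

Still open, as far as these compounds go, is whether other groups at this place, such as an amine or a carboxylic acid, behave like methoxy and nitro. From the compounds shown here alone, it is also open whether a longer chain on the ester carries the series further, and whether the acetyl and ethyl ester differ in the same way with the 4-methoxyphenyl in place.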